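A longer bromoalkoxy chain on the shared core

A few compounds are considered here, and "the series" means these few. Any claim that something is new, unique, unknown or untested is made for them only; others in the source may bear on it.

Measured so far in a functional assay on HeLa cells (Homo sapiens) for antiproliferative activity, read by MTT assay, with a stated time of 48 h (a lower number here means a stronger inhibitor, a higher number a weaker inhibitor), are two compounds
- compound 1 (`COc1ccc(N(C)c2ccnc(Cl)n2)cc1Cl`) gives 517 nM
- compound 2 (`COc1ccc(N(C)c2ccnc(Cl)n2)cc1OCCBr`) gives 3310 nM

Compound 2 holds the higher of the two numbers and is the weaker inhibitor of the pair. Compound 3 (`COc1ccc(N(C)c2ccnc(Cl)n2)cc1OCCCCCBr`) has not yet been measured. It differs from compound 2 by 3-bromopropyl in place of bromo on a saturated chain carbon, two bonds along the chain from an oxygen on an aromatic ring, which turns 2-bromoethoxy into (5-bromopentyl)oxy. Among the measured compounds shown here, only one measured step bears on this change, and only indirectly. That step is a 6.4-fold higher number from compound 1 to compound 2 (0.81 log units; beyond the scatter), where 2-bromoethoxy replaced chloro. For the measured compounds named here, no measured pair tests chain length alone, so the direction remains open and no shift beyond the scatter is expected. The expected change is a 1.2-fold lower number from compound 2 to compound 3 (0.07 log units; within the scatter) in this assay. For compound 3 the estimate is 2800 nM, with an expected range from 700 nM to 11000 nM.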

Compound 3, half-maximal inhibitory concentration: 7090 nM
Estimate against measurement, compound 3: 2.5-fold (0.40 log units) below, within the range that was stated.
By their numbers in this assay, from the lowest: compound 1; then compound 2; then compound 3.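

Lengthening the chain, with 3-bromopropyl in place of bromo on a saturated chain carbon, two bonds along the chain from an oxygen on an aromatic ring, gives a 2.1-fold higher number from compound 2 to compound 3 (0.33 log units; beyond the scatter) in this assay, and this is the first measured pair in which only the chain length changes. Set against the chloro group of compound 1, the longer group gives a 14-fold higher number from compound 1 to compound 3 (1.14 log units; beyond the scatter), so the number rises from chloro through 2-bromoethoxy to (5-bromopentyl)oxy, and none of the three compounds goes against that order. No measured evidence accounts for this rise.

On these data alone, whether a longer chain would raise the number further remains open. So does whether the step belongs to the chain or to the bromo on it, which a plain pentyloxy group or an amine in place of bromo could separate.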